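The source may hold more compounds than are shown below. What is called first, only, known or untested is meant among the compounds shown, and "the series" means these compounds.

In an ADME assay on HEK293 cells (Homo sapiens) for cytotoxicity, read by resazurin assay, with a stated time of 72 h (a higher number here means that more compound is tolerated, a lower number that less compound is tolerated), compound 1 `CCc1cccc(CNC(=O)c2nc3cccc(CSCc4ccc(C(=O)O)cc4)c3c(=O)[nH]2)c1` gives > 20000 nM as a limit of the assay and not a number. Compound 2 `CCc1cccc(CNC(=O)c2nc3cccc(COCc4cccc(C(=O)O)c4)c3c(=O)[nH]2)c1` gives > 20000 nM as a limit too, so its standing is known only as a limit. All the evidence so far amounts to the limit of > 20000 nM in this assay, at which 2 of the 2 values shown sit, and nothing finer. Compound 3 `CCc1cccc(CNC(=O)c2nc3cccc(COCc4ccc(C(N)=O)cc4)c3c(=O)[nH]2)c1` has not yet been measured. It differs from compound 2 by 4-carbamoylphenyl in place of 3-carboxyphenyl on a saturated chain carbon bound to an oxygen on a saturated carbon with 4-carbamoylphenyl in place of 3-carboxyphenyl on a saturated chain carbon bound to an oxygen on a saturated carbon. Going by the values given here, only one measured step bears on this change, a step that the two limits leave unreadable from compound 1 to compound 2 and it offers no size to carry over. The expected size of a step that the limit leaves unreadable from compound 2 to compound 3 stays within the usual scatter in this assay with no direction favoured. Compound 3 is estimated at 22000 nM with an expected range from 9000 nM to 50000 nM and may well return only a limit again.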

Compound 3, half-maximal cytotoxic concentration: > 20000 nM
Compound 3 was reported as a limit; the forecaster's own chance of this, stated with the estimate: 80%; the middle value does not contradict the limit.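

Going by these compounds alone, compound 1, compound 2 and compound 3 each return only a limit of the assay and not a number, so no step between them can be read. Left open is the concentration at which any of them would reach the half-maximal cytotoxic level in this assay, and whether the changes among them shift it.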